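Chalcone-type pyrazoles: swapping the ketone aryl group

A few compounds are considered here, and "the series" means these few. Any claim that something is new, unique, unknown or untested is made for them only; others in the source may bear on it.

Measured so far:
compound 1, `COc1ccc(C(=O)/C=C/c2cn(-c3ccccc3)nc2-c2ccsc2)cc1OC`, 2800 nM
compound 2, `O=C(/C=C/c1cn(-c2ccccc2)nc1-c1cccnc1)c1ccsc1`, 500 nM

In a functional assay on MCF7 cells (Homo sapiens) for inhibition, read by sulforhodamine B assay, with a stated time of 72 h (a lower number here means a stronger inhibitor, a higher number a weaker inhibitor), compound 2 gives the lower of the two numbers, and compound 1 gives the higher; the gap between them lies beyond the scatter. The two structures differ in two places at once, so no single step can be read from them. Compound 3, `COc1ccc(OC)c(C(=O)/C=C/c2cn(-c3ccccc3)nc2-c2cccnc2)c1`, keeps the pyridinyl-bearing core of compound 2 and changes only the ketone end: 2,5-dimethoxyphenyl in place of thiophen-3-yl on a carbonyl carbon. Among the compounds with values here, the only guide is compound 1, whose dimethoxyphenyl ketone came with the weaker number 2800 nM. The step is therefore expected to go toward weaker inhibition, by a modest amount, as a 2.4-fold higher number from compound 2 to compound 3 (0.38 log units; beyond the scatter). Compound 3 is estimated at 1200 nM, in the range 400 nM to 4000 nM.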

Compound 3, half-maximal inhibitory concentration: 1500 nM
Estimate against measurement, compound 3: 1.3-fold (0.10 log units) below, and the stated range covers the measured number.
By their numbers in this assay, from the lowest: compound 2; then compounds 3 and 1 (each within the scatter of the next).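

Within this assay the swap from thiophen-3-yl to 2,5-dimethoxyphenyl on a carbonyl carbon brings a 3.0-fold higher number from compound 2 to compound 3 (0.48 log units; beyond the scatter) and is the first change at this position that can be read alone. With the rest of the structure held constant, the ketone aryl group thus moves the number beyond the scatter, and thiophen-3-yl gives the lower value of this pair. Nothing measured here bears on the reason for this step. Still open, going by these compounds, is whether the two methoxy groups or the ring itself accounts for the step, which an unsubstituted phenyl ketone would help to separate.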